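Phthalimide amides: furan to thiazole on the carbonyl

This account rests on a few compounds, and the source may have more. Where it says the series, first, only, none or still open, it means among the compounds named here.

The series shares a core carrying a phthalimide-methyl group and a halogen, with an amide on the aniline nitrogen whose acyl group is varied. Compound 1 `O=C(Nc1ccc(Cl)cc1CN1C(=O)c2ccccc2C1=O)c1ccccc1[N+](=O)[O-]` gives 5700 nM in an assay on CHO cells for positive allosteric modulation of metabotropic glutamate receptor 5 (Homo sapiens), read by FLIPR; on this read-out lower numbers stand for an effect already at smaller amounts and higher numbers for an effect only at larger amounts of compound. Compound 2 `O=C(Nc1ccc(F)cc1CN1C(=O)c2ccccc2C1=O)c1ccccn1` gives 1500 nM in this assay. Compound 3 `O=C(Nc1ccc(Cl)cc1CN1C(=O)c2ccccc2C1=O)c1ccco1` gives 2300 nM in this assay. Of the three, compound 3 stands second highest: its number is the higher one beside compound 2, but that gap lies within the scatter, while the gap to compound 1 is beyond it, as a 2.5-fold lower number from compound 1 to compound 3 (0.39 log units; beyond the scatter) shows a modest step for the acyl swap.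

Compound 4 `O=C(Nc1ccc(Cl)cc1CN1C(=O)c2ccccc2C1=O)c1cncs1` differs from compound 3 by 1,3-thiazol-5-yl in place of furan-2-yl on a carbonyl carbon. Within the data shown here, the only measured step at this position, a 2.5-fold lower number from compound 1 to compound 3 (0.39 log units; beyond the scatter), replaced a six-membered carbocycle by a five-membered heteroaryl and was modest; the change from compound 3 to compound 4 keeps a five-membered heteroaryl on the carbonyl and adds one acceptor. Among the measured compounds shown here, no measured pair shows an exchange of this kind, so for compound 4 in this assay the expected step, a 1.2-fold lower number from compound 3 to compound 4 (0.06 log units; within the scatter), is none beyond the scatter. Compound 4 is therefore estimated at 2000 nM, with a range from 800 nM to 6000 nM.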

Compound 4, half-maximal effective concentration: 1900 nM
Compound 4: the middle estimate sits 1.1-fold (0.02 log units) above what was measured; the range from low to high includes it.
By their numbers in this assay, from the lowest: compounds 2, 4 and 3 (each within the scatter of the next); then compound 1.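

In this assay, putting 1,3-thiazol-5-yl in place of furan-2-yl on the carbonyl carbon gives a 1.2-fold lower number from compound 3 to compound 4 (0.08 log units; within the scatter): a five-membered aromatic ring with 2 hetero atoms and 2 hydrogen-bond acceptors reads the same here as one with 1 hetero atom and 1 hydrogen-bond acceptor. Replacing 2-nitrophenyl with 1,3-thiazol-5-yl gives a 3.0-fold lower number from compound 1 to compound 4 (0.48 log units; beyond the scatter), which, like a 2.5-fold lower number from compound 1 to compound 3 (0.39 log units; beyond the scatter), is modest and beyond the scatter, so the difference from compound 1 now rests on two five-membered aromatic rings rather than on furan-2-yl alone. No data at hand bear on why these steps take the size they do.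

The compounds shown do not separate the size of the ring from the presence of the nitro group, and a plain phenyl on the carbonyl of the core of compound 3 would speak to that. Also open, as far as these compounds go, is whether this position needs an aromatic ring at all, which a morpholine or a short alkyl chain in its place would test.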